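A few compounds are considered here, and "the series" means these few. Any claim that something is new, unique, unknown or untested is made for them only; others in the source may bear on it.

Compound 1 `Cn1c(COc2cccc(C(=O)O)c2)nc2ccc(Oc3ccccn3)cc21` gives 0.4 in a physicochemical assay for lipophilicity, read by LC-MS, in phosphate buffer, measured as octanol-water partition, with a stated time of 30 min, at pH 7.4, tested at 200 mM; a higher number here means a more lipophilic compound, a lower number a more polar compound.
Compound 2 `Cn1c(COc2cccc(C(=O)O)c2)nc2ccc(Oc3cccc(Cl)n3)cc21` gives 1.2 in this assay.
Compound 3 `Cn1c(COc2cccc(C(=O)O)c2)nc2ccc(Oc3cc(Cl)ccn3)cc21` gives 1.2 in this assay.

Compound 3 shares with compound 2 the highest reading of the three: the move from compound 2 to compound 3 is no change at the digits printed from compound 2 to compound 3 (within the scatter), while from compound 1 to compound 3 the reading is a number 0.80 log units higher from compound 1 to compound 3 (beyond the scatter). The two chloro compounds thus sit together, well apart from the unsubstituted parent.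

Compound 4 `Cn1c(COc2cccc(C(=O)O)c2)nc2ccc(Oc3ncccc3Cl)cc21` differs from compound 3 in one place: 3-chloropyridin-2-yl in place of 4-chloropyridin-2-yl on an oxygen on an aromatic ring. The chlorine stays on the pyridine ring but moves to another position, a change of the same kind as that between compound 2 and compound 3.

Going by the values given here, the steps that bear on this are two. Introducing the chloro gave a number 0.80 log units higher from compound 1 to compound 2 (beyond the scatter) and a number 0.80 log units higher from compound 1 to compound 3 (beyond the scatter); moving the chloro from one ring position to another gave no change at the digits printed from compound 2 to compound 3 (within the scatter). Since compound 4 keeps the chloro and only shifts it, the move from compound 3 to compound 4 is expected to be no change at the digits printed from compound 3 to compound 4 (within the scatter), that is, nothing beyond the scatter. Compound 4 is therefore estimated at 1.2, within 0.9 to 1.5.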

Compound 4, distribution coefficient: 1.1
The estimate for compound 4 lay 0.10 log units above the measured number; low and high end bracket the measured number.
By their numbers in this assay, from the lowest: compound 1; then compounds 4, 2 and 3 (each within the scatter of the next).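

In this assay, the reading with 3-chloropyridin-2-yl on the oxygen is a number 0.10 log units lower from compound 3 to compound 4 (within the scatter) and a number 0.10 log units lower from compound 2 to compound 4 (within the scatter), so this third place for the chloro gives a reading no different from the other two. The rise over the unsubstituted pyridine also holds here, at a number 0.70 log units higher from compound 1 to compound 4 (beyond the scatter), so compound 2, compound 3 and compound 4 all stand clear of compound 1 wherever the chloro sits among these three places. No measurement is available to explain why moving the chloro leaves the number in place.

Still open, from the compounds shown here alone, is whether a methyl, a methoxy or an amine in the same places would track the chloro or would make the ring position matter. Going by these compounds, whether a second chloro on the pyridine would raise the number further is also open.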